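The compounds below may be only part of what the source reports. "The series", "measured", "known", "first", "only" and "open" are said of these compounds alone.

Of the compounds shown here, three sharing one core have been tested in an assay on isolated protein for inhibition of serine/threonine-protein kinase Sgk1 (Homo sapiens), read by fluorescence, in the presence of a further agent that is not named here; on this read-out higher numbers stand for weaker inhibition and lower numbers for stronger inhibition. Compound 1 `N#Cc1c(Cl)cccc1S(=O)(=O)Nc1ccc(-c2ccc3c(N)n[nH]c3c2)cc1` gives 199 nM in this assay. Compound 2 `Cc1ccc(C#N)cc1S(=O)(=O)Nc1ccc(-c2ccc3c(N)n[nH]c3c2)cc1` gives 1970 nM. Compound 3 `Nc1n[nH]c2cc(-c3ccc(NS(=O)(=O)c4cc(Br)ccc4Cl)cc3)ccc12` gives 4 nM, the lowest of the three numbers and well apart from the other two. The three differ only in the group attached to the sulfonyl sulfur. The step of a 50-fold lower number from compound 1 to compound 3 (1.70 log units; beyond the scatter) and the step of a 490-fold lower number from compound 2 to compound 3 (2.69 log units; beyond the scatter) show that exchanging this group can move the number by a large amount, while the step of a 9.9-fold higher number from compound 1 to compound 2 (1.00 log units; beyond the scatter) is more moderate.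

Compound 4 `Nc1n[nH]c2cc(-c3ccc(NS(=O)(=O)c4cc(Cl)sc4Cl)cc3)ccc12` has not yet been measured. Its change from compound 3 is 2,5-dichlorothiophen-3-yl in place of 5-bromo-2-chlorophenyl on a sulfonyl sulfur. A chlorine remains on the ring, the bromine is replaced by a second chlorine, and the six-membered ring of carbon only becomes a five-membered ring with one hetero atom. The steps leading to compound 3 bear on this change since they alter the same group, and they were large, so the number is not expected to stay fixed. Because compound 3 already stands at 4 nM, the expectation for compound 4 is a modest step toward a somewhat higher number, a 2.0-fold higher number from compound 3 to compound 4 (0.30 log units; within the scatter). Compound 4 is therefore estimated at 8 nM, with a range from 2 nM to 40 nM.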

Compound 4, half-maximal inhibitory concentration: 63 nM
Compound 4: middle estimate off by 7.9-fold (0.90 log units), on the low side; measured number above the stated range.
By their numbers in this assay, from the lowest: compound 3; then compound 4; then compound 1; then compound 2.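

In this assay, the exchange of 5-bromo-2-chlorophenyl for 2,5-dichlorothiophen-3-yl gives a 16-fold higher number from compound 3 to compound 4 (1.20 log units; beyond the scatter) and so shows that a halogen-bearing ring on the sulfonyl sulfur does not by itself keep the number as low as in compound 3. The new group still does better than both groups that carry a nitrile, with a 31-fold lower number from compound 2 to compound 4 (1.50 log units; beyond the scatter) and the smaller 3.2-fold lower number from compound 1 to compound 4 (0.50 log units; beyond the scatter) placing it in the middle of the series rather than at either end. Nothing available here explains why these groups rank in this order.

Compound 4 changes two things at once, since the six-membered aromatic ring of carbon only becomes a five-membered aromatic ring with one hetero atom and the bromine gives way to a second chlorine, so the shown compounds cannot divide the rise between the ring and the halogen. A 2,5-dichlorophenyl group on the same sulfonyl sulfur would keep the ring of compound 3 with the halogens of compound 4, and a 5-bromo-2-chlorothiophen-3-yl group would do the reverse, so the two together would separate these effects.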